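Moving the Fluorine Around the Benzyl Ring

The compounds below may be only part of what the source reports. "The series", "measured", "known", "first", "only" and "open" are said of these compounds alone.

Of the compounds shown here, three have been measured in a physicochemical assay for lipophilicity, at pH 7.4; on this read-out lower numbers stand for lower lipophilicity and higher numbers for higher lipophilicity. Compound 1 `CNC(=O)c1cc(C(=O)NC2CC2)cn(Cc2ccc3nc[nH]c3c2)c1=O` gives 1.2, compound 2 `CNC(=O)c1cc(C(N)=O)cn(Cc2ccccc2)c1=O` gives 2, and compound 3 `CNC(=O)c1cc(C(=O)NC2CC2)cn(Cc2ccc(F)cc2)c1=O` gives 3.2, the highest of the three. Among the measured compounds shown here, the only step between measured compounds that differ in a single place is a number 2.00 log units higher from compound 1 to compound 3 (beyond the scatter); compound 2 differs from compound 3 in more than one place, and its value lies lower. Compound 4 `CNC(=O)c1cc(C(=O)NC2CC2)cn(Cc2ccccc2F)c1=O` has not yet been measured. It differs from compound 3 by 2-fluorophenyl in place of 4-fluorophenyl on a saturated chain carbon bound to an aromatic nitrogen. For the measured compounds named here, no measured step shifts a fluorine from one position to another on the same ring, so the earlier step does not bear directly on this change; nothing among the measured compounds points to a shift beyond the scatter. For compound 4 the expected step is a number 0.10 log units lower from compound 3 to compound 4 (within the scatter), within the scatter. Compound 4 is therefore estimated at 3.1, in the range 2.7 to 3.5.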

Compound 4, distribution coefficient: 3
For compound 4 the middle estimate is 0.10 log units above the measured one, within the range that was stated.
By their numbers in this assay, from the lowest: compound 1; then compound 2; then compounds 4 and 3 (each within the scatter of the next).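

The step of a number 0.20 log units lower from compound 3 to compound 4 (within the scatter) in this assay shows that, on a saturated chain carbon bound to an aromatic nitrogen, 2-fluorophenyl and 4-fluorophenyl cannot be told apart on this read-out. The large step seen earlier with 4-fluorophenyl in place of 1H-benzimidazol-6-yl also appears with the other fluorophenyl, as a number 1.80 log units higher from compound 1 to compound 4 (beyond the scatter) shows, so here it does not depend on which of these two fluorophenyl groups is present. Nothing shown explains why the two fluorophenyl groups read alike.

Open, on these data alone, is whether a chlorine, a nitrile or an amine on the ring in place of the fluorine would stay as close to these compounds. Also open, as far as these compounds go, is how either fluorophenyl compares with a plain phenyl on the core of compound 3.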